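Three Analogues at the Limit and an Aryl Amide Newcomer

This account rests on a few compounds, and the source may have more. Where it says the series, first, only, none or still open, it means among the compounds named here.

Compound 1 `O=C(NCC1CCCCC1)c1cccc(/C=C2\CC(=O)N(c3ccccc3)C2=O)c1` was tested in an ADME assay on NCM460 cells (Homo sapiens) for cytotoxicity, read by MTT assay, with a stated time of 72 h (a higher number here means a weaker inhibitor, a lower number a stronger inhibitor), and compound 1 gives > 100000 nM, which is a limit of the assay rather than a number. Compound 2 `CCCCCN1C(=O)C/C(=C\c2cccc(C(=O)NCCCC)c2)C1=O` likewise reaches only a limit in this assay, giving > 100000 nM. Compound 3 `COc1ccc(NC(=O)c2cccc(/C=C3\CC(=O)N(c4ccc(C)cc4)C3=O)c2)cc1` also sits at a limit, giving > 100000 nM. Compound 1 therefore stands exactly where every measured value stands: the limit of > 100000 nM in this assay, at which 3 of the 3 values shown sit, with no number below that limit among the three.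

Compound 4 `COc1ccc(NC(=O)c2cccc(/C=C3\CC(=O)N(c4ccccc4)C3=O)c2)c(C)c1` has not yet been measured in this assay. It differs from compound 1 in one place (4-methoxy-2-methylphenyl in place of cyclohexylmethyl on an amide-type nitrogen), at an amide-type nitrogen whose other neighbour is a carbonyl carbon. Among the compounds with values here, no pair among compounds 1, 2 and 3 is a single-point step, so no size of step has been observed. With all three values resting at a limit, the step of a number no higher from compound 1 to compound 4 (the limit leaves the size open) is expected to stay within the usual scatter, with no direction favoured. Compound 4 is accordingly estimated at 100000 nM, within a range from 50000 nM to 200000 nM, and the most likely outcome is that this assay once more reports only its limit.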

Compound 4, half-maximal inhibitory concentration: > 100000 nM
Compound 4: a limit, no number; the forecaster's own chance of this, stated with the estimate: 85%; the middle value sits exactly at the limit.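

In this assay compound 4 gives > 100000 nM, a limit and not a number. Compound 1 also rests at a limit, and no step can be read between compound 1 and compound 4. The compounds shown leave open how far any of them lies from that limit: the limit of > 100000 nM in this assay, at which 4 of the 4 values shown sit.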